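Chloro for fluoro on the fused ring of compound 3

A few compounds are considered here, and "the series" means these few. Any claim that something is new, unique, unknown or untested is made for them only; others in the source may bear on it.

Measured compounds:
compound 1, `O=S(=O)(c1ccc(F)cc1)c1cnc2cc(F)c(Cl)cc2c1-c1ccc(Cl)cc1`, 43.7%
compound 2, `O=S(=O)(c1ccc(F)cc1)c1cnc2cc(Cl)c(F)cc2c1-c1ccc(Cl)cc1`, 48%
compound 3, `O=S(=O)(c1ccc(F)cc1)c1cnc2cc(F)ccc2c1-c1ccc(Cl)cc1`, 91.6%

In an assay on cell membranes for displacement of a labelled ligand from metabotropic glutamate receptor 5 (Rattus norvegicus), with a stated time of 60 min, tested at 1 uM (a higher number here means more inhibition at the concentration tested (going by the name of the read-out), a lower number less inhibition), compound 3 stands highest of the three, beyond the scatter from compound 2 and from compound 1. Compound 4, `O=S(=O)(c1ccc(F)cc1)c1cnc2cc(Cl)ccc2c1-c1ccc(Cl)cc1`, is still to be measured; it differs from compound 3 in one place: chloro in place of fluoro on an aromatic carbon. Among the measured compounds shown here, only one measured step touches a chloro on that ring, a number 47.9 percentage points higher from compound 1 to compound 3 (beyond the scatter), and there removing the chloro raised the number strongly. Compounds 1 and 2, which both carry a chloro on the fused ring, are far lower than compound 3. Compound 4 is therefore expected to fall below compound 3 by a step of a number 23.6 percentage points lower from compound 3 to compound 4 (beyond the scatter), and its estimated value in this assay is 68%, within 45% to 90%.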

Compound 4, a percentage reported as inhibition, at one concentration (the size of the read-out at that concentration, not a potency): 92.8%
The estimate for compound 4 lay 24.8 percentage points below the measured number, outside the stated range (above it).
By their numbers in this assay, from the lowest: compounds 1 and 2 (each within the scatter of the next); then compounds 3 and 4 (each within the scatter of the next).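

In this assay chloro and fluoro at this position cannot be told apart, with a number 1.2 percentage points higher from compound 3 to compound 4 (within the scatter) and so a chloro on this carbon does not by itself go with a low number. Compound 2 keeps that chloro and adds a fluoro on a further aromatic carbon, and hydrogen in place of that fluoro gives a number 44.8 percentage points higher from compound 2 to compound 4 (beyond the scatter) so the low number of compound 2 goes with the added fluoro, not with the chloro. Nothing available explains these results. As far as these compounds go, whether a methoxy group or an amine on this carbon would keep the number as high stays open. From the compounds shown here alone, with a single tested concentration, how the potencies of compound 3 and compound 4 compare also stays open.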